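Replacing the 2,4-dimethoxyphenyl group of compound 1

The source may report more compounds than this note shows. Statements on the series, on what has been measured and on what is new or still open speak of the compounds shown alone.

Compound 1 `COc1ccc(/C=C/C(=O)Nc2cc3c(Nc4ccc(F)c(Cl)c4)ncnc3cc2O[C@H]2CCOC2)c(OC)c1`: 9350 nM
Compound 2 `COc1ccc(/C=C/C(=O)Nc2cc3c(Nc4ccc(F)c(Cl)c4)ncnc3cc2OC)cc1`: "not active" (no number reported)
Compound 3 `COc1ccc(/C=C/C(=O)Nc2cc3c(Nc4ccc(F)c(Cl)c4)ncnc3cc2OC)c(OC)c1`: 33300 nM

Among the measured compounds shown here, in a functional assay on A549 cells (Homo sapiens) for cytotoxicity, read by MTT assay, with a stated time of 72 h (a higher number here means a weaker inhibitor, a lower number a stronger inhibitor), compound 1 gives 9350 nM as the lower of the only two numbers available. Compound 3 is the nearest, and compound 2 has no number at all. Compound 4 `O=C(/C=C/c1cc(Br)c(O)c(Br)c1)Nc1cc2c(Nc3ccc(F)c(Cl)c3)ncnc2cc1O[C@H]1CCOC1` has not yet been measured. Its difference from compound 1 is 3,5-dibromo-4-hydroxyphenyl in place of 2,4-dimethoxyphenyl on a double-bonded chain carbon bound to a double-bonded chain carbon and this exchange takes place on a double-bonded chain carbon bound to a double-bonded chain carbon.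

For the measured compounds named here, no measured step covers this exchange. Going by the values given here, the only step, a 3.6-fold higher number from compound 1 to compound 3 (0.55 log units; beyond the scatter) with methyl in place of oxolan-3-yl on an oxygen on an aromatic ring, is modest but beyond the scatter, and it lies elsewhere in the molecule. Closer to the change, compound 2 is reported as "not active" (no number reported) while compound 3 gives 33300 nM in this assay and these two differ in the aromatic group at the same place. The read-out may therefore respond to this group, but the data give no direction for a 3,5-dibromo-4-hydroxyphenyl group. The estimated step is a 1.6-fold lower number from compound 1 to compound 4 (0.19 log units; within the scatter) with only a weak lean to a lower number, so no firm move beyond the scatter is expected. Compound 4 is expected at an estimated 6000 nM within a range from 1500 nM to 25000 nM in this estimate.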

Compound 4, half-maximal inhibitory concentration: 28800 nM
For compound 4 the middle estimate is 4.8-fold (0.68 log units) below the measured one; the whole stated range lies below it.
By their numbers in this assay, from the lowest: compound 1; then compounds 4 and 3 (each within the scatter of the next).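

In this assay, 3,5-dibromo-4-hydroxyphenyl in place of 2,4-dimethoxyphenyl on a double-bonded chain carbon bound to a double-bonded chain carbon gives a 3.1-fold higher number from compound 1 to compound 4 (0.49 log units; beyond the scatter). Among the compounds shown here, this is the first step with a number and a direction at this position, which the earlier compounds could not supply, as compound 2 has no number and the only earlier step lies elsewhere in the molecule. The exchange removes both methoxy groups and brings in bromine and a hydrogen-bond donor all at once. The step cannot be divided among these features, and nothing measured here offers a cause for it.

On these data alone, what a 4-hydroxyphenyl group without bromine or a 3,5-dibromophenyl group without the hydroxy group would give at this place remains open, and so does the effect of a 4-aminophenyl group or a pyridine ring there. As far as these compounds go, it is also open whether this exchange would give a step of similar size with methyl in place of oxolan-3-yl on an oxygen on an aromatic ring.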